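Swapping 4-methylphenyl for 3-bromophenyl: compound 3 to compound 4

The compounds below may be only part of what the source reports. "The series", "measured", "known", "first", "only" and "open" are said of these compounds alone.

Measured in a functional assay on B16-F10 cells (Mus musculus) for antiproliferative activity, read by MTT assay, with a stated time of 48 h; a higher number here means a weaker inhibitor, a lower number a stronger inhibitor
Compound 1 `CCCCCCCCCCCCOc1ccc(C(=O)/C=C/c2c(/C=C/c3ccc(OC)cc3)cc(OC)cc2OC)cc1` gives 12.7 ug/mL
Compound 2 `COc1ccc(/C=C/c2cc(OC)cc(OC)c2/C=C/C(=O)c2ccc(Cl)c(Cl)c2)cc1` gives 7.5 ug/mL
Compound 3 `COc1ccc(/C=C/c2cc(OC)cc(OC)c2/C=C/C(=O)c2ccc(C)cc2)cc1` gives 5.3 ug/mL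

In this assay compound 3 at 5.3 ug/mL lies within the scatter of compound 2 at 7.5 ug/mL and sits under compound 1 at 12.7 ug/mL by more than the scatter. Compound 4 `COc1ccc(/C=C/c2cc(OC)cc(OC)c2/C=C/C(=O)c2cccc(Br)c2)cc1` differs from compound 3 by 3-bromophenyl in place of 4-methylphenyl on a carbonyl carbon in one place, with 3-bromophenyl in place of 4-methylphenyl on a carbonyl carbon. For the measured compounds named here, the one measured step at that place is a 1.4-fold lower number from compound 2 to compound 3 (0.15 log units; within the scatter) and stays within the scatter. That single step is little to go on, so no change beyond the scatter is expected in this assay and no direction can be told. The expected move is a 1.1-fold higher number from compound 3 to compound 4 (0.05 log units; within the scatter) and stays within the scatter. Compound 4 is expected at 6 ug/mL within an estimated range of 3 ug/mL to 12 ug/mL once measured.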

Compound 4, half-maximal inhibitory concentration: 5.1 ug/mL
Beside the measured number, compound 4's estimate is 1.2-fold (0.07 log units) above it, within the range that was stated.
By their numbers in this assay, from the lowest: compounds 4, 3, 2 and 1 (each within the scatter of the next, the first and the last beyond it).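

In this assay, this place on the carbonyl carbon now holds a third group that cannot be told apart from the others: changing the group gives a 1.0-fold lower number from compound 3 to compound 4 (0.02 log units; within the scatter) and a 1.5-fold lower number from compound 2 to compound 4 (0.17 log units; within the scatter). So 4-methylphenyl, 3,4-dichlorophenyl and 3-bromophenyl read alike here, even though the group entering compound 4 carries bromine instead of a methyl group or two chlorines. Nothing measured here explains this sameness. Still open, from the compounds shown here alone, is whether 4-bromophenyl, or a phenyl ring carrying an amine or a carboxylic acid, would read differently at this place.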